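Swapping methoxy for methylamino on a nucleoside core

The source may report more compounds than this note shows. Statements on the series, on what has been measured and on what is new or still open speak of the compounds shown alone.

Measured so far:
compound 1 `COc1ncnc2c1c(-c1ccsc1)cn2[C@@H]1O[C@H](CO)[C@@H](O)[C@H]1O` – 2570 nM
compound 2 `COc1ncnc2c1c(-c1ccccc1)cn2[C@@H]1O[C@H](CO)[C@@H](O)[C@H]1O` – > 20000 nM

Going by the values given here, in a functional assay on CCRF-CEM cells (Homo sapiens), read by MTT assay, with a stated time of 72 h (on this read-out higher numbers stand for weaker inhibition and lower numbers for stronger inhibition), compound 1 gives 2570 nM, the only measured number in the set. Compound 2 reaches only the assay limit of > 20000 nM, not a number. Among the compounds with values here, the one measured step, an at least 7.7-fold higher number from compound 1 to compound 2 (0.89 log units; beyond the scatter), concerns the aromatic group on the core and is at least modest; it sits at the limit of > 20000 nM in this assay, at which 1 of the 2 values shown sits.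

Compound 3 `CNc1ncnc2c1c(-c1ccsc1)cn2[C@@H]1O[C@H](CO)[C@@H](O)[C@H]1O` differs from compound 1 at another place: methylamino in place of methoxy on an aromatic carbon. The methoxy leaves and a methylamino enters on an aromatic carbon of the shared core. Within the data shown here, no measured step touches this position, so the step from compound 1 to compound 2 does not bear on it, and there is no basis for expecting a change beyond the scatter in either direction.

Compound 3 is therefore estimated at 1800 nM, within 300 nM to 9000 nM, an expected step of a 1.4-fold lower number from compound 1 to compound 3 (0.15 log units; within the scatter).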

Compound 3, half-maximal inhibitory concentration: > 20000 nM
Compound 3 gave a limit, no number; the forecaster's own chance of this, stated with the estimate: 10%; middle value at least 11-fold (1.04 log units) from the limit.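

In this assay, going by these compounds alone, methylamino in place of methoxy gives an at least 7.7-fold higher number from compound 1 to compound 3 (0.89 log units; beyond the scatter), so this position on the shared core clearly affects the read-out, something no earlier step could show. Compound 3 reaches > 20000 nM, which is a limit of the assay and not a number. The step therefore gives only a minimum size, and the real gap stays unknown, with the assay limit now reached by two different single changes to compound 1: the limit of > 20000 nM in this assay, at which 2 of the 3 values shown sit.

The compounds shown leave open how other groups would read at this position, such as an unsubstituted amine, a dimethylamino group or an ethoxy group. They also do not show which feature of methylamino matters, so a number for any such group would be needed to tell how narrow the requirement here is.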